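A few compounds are considered here, and "the series" means these few. Any claim that something is new, unique, unknown or untested is made for them only; others in the source may bear on it.

Compound 1 `Cc1ccc(S(=O)(=O)NCc2ccc(CNC(=O)c3ccccc3)cc2)cc1` is the unsubstituted benzoyl member of the series. In an assay on MDA-MB-231 cells for binding affinity to C-X-C chemokine receptor type 4 (Homo sapiens), read by immunofluorescence and microscopy, with stated times of 10 min and 30 min (on this read-out lower numbers stand for an effect already at smaller amounts and higher numbers for an effect only at larger amounts of compound), compound 1 gives > 1000 nM, which is a limit of the assay and not a number; compound 1 therefore stands at the limit of > 1000 nM in this assay, at which 1 of the 3 values shown sits. Compound 2 `Cc1ccc(S(=O)(=O)NCc2ccc(CNC(=O)c3cccc(Cl)c3)cc2)cc1` gives 100 nM and compound 3 `Cc1ccc(S(=O)(=O)NCc2ccc(CNC(=O)c3cccc(F)c3)cc2)cc1` gives 1 nM in this assay. The measured steps are an at least 10-fold lower number from compound 1 to compound 2 (1.00 log units; beyond the scatter), an at least 1000-fold lower number from compound 1 to compound 3 (3.00 log units; beyond the scatter) and a 100-fold lower number from compound 2 to compound 3 (2.00 log units; beyond the scatter). Compound 4 `Cc1ccc(S(=O)(=O)NCc2ccc(CNC(=O)c3ccccc3C)cc2)cc1` differs from compound 1 by methyl in place of hydrogen on an aromatic carbon. Both steps from compound 1 concern chloro or fluoro on the benzoyl and both lower the number; methyl is neither, and its place differs, so only a modest lowering is expected. For compound 4 the expected value is 300 nM, with a range from 30 nM to 3000 nM. The step expected is an at least 3.3-fold lower number from compound 1 to compound 4 (0.52 log units; beyond the scatter).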

Compound 4, effective concentration (reported as EC, without a stated level of effect): 100 nM
Compound 4: the middle estimate sits 3.0-fold (0.48 log units) above what was measured, within the range that was stated.
By their numbers in this assay, from the lowest: compound 3; then compounds 2 and 4 (each within the scatter of the next). At a limit, above all of these: compound 1.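

Methyl ortho to a large group also lowers the number, so the drop on the benzoyl is not confined to chloro or fluoro (an at least 10-fold lower number from compound 1 to compound 4 (1.00 log units; beyond the scatter)). The value of compound 1 is a limit of the assay and not a number: the limit of > 1000 nM in this assay, at which 1 of the 4 values shown sits. The 2-methylphenyl and 3-chlorophenyl groups read alike (no change at the digits printed from compound 2 to compound 4 (within the scatter)), whereas the 3-fluorophenyl group stays well apart (a 100-fold higher number from compound 3 to compound 4 (2.00 log units; beyond the scatter)).

On these data alone, whether fluoro keeps its value when ortho to a large group remains open. So does the outcome with an amine, a carboxylic acid or a longer chain on that ring.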